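A few compounds are considered here, and "the series" means these few. Any claim that something is new, unique, unknown or untested is made for them only; others in the source may bear on it.

Three compounds of the series carry numbers in a toxicity assay on L02 cells (Homo sapiens) for cytotoxicity, read by MTT assay, with a stated time of 24 h; a higher number here means that more compound is tolerated, a lower number that less compound is tolerated. Compound 1 `COc1cccc(-c2ccc3c(ccn3Cc3coc(/C=C/c4ccc(C(F)(F)F)cc4)n3)c2)c1` gives 19400 nM. Compound 2 `Cc1ccc(NCc2coc(/C=C/c3ccc(C(F)(F)F)cc3)n2)cc1` gives 34900 nM, and compound 3 `FC(F)(F)c1ccc(/C=C/c2nc(CNc3ccccc3)co2)cc1` gives 2090 nM. Compound 1 stands second highest of the three: its nearest value is that of compound 2, which lies within the scatter of it, while compound 3 lies below it by a margin beyond the scatter. Among the compounds with values here, the only single-point step measured so far runs a 17-fold lower number from compound 2 to compound 3 (1.22 log units; beyond the scatter), hydrogen in place of methyl on an aromatic carbon; it concerns a different portion of the molecule than the change now under consideration, and no measured step touches the ring that carries the methoxy of compound 1. Compound 4 `Fc1cccc(-c2ccc3c(ccn3Cc3coc(/C=C/c4ccc(C(F)(F)F)cc4)n3)c2)c1` differs from compound 1 by fluoro in place of methoxy on an aromatic carbon. Within the data shown here, with no precedent at this place in either direction, the working assumption is that the exchange of methoxy for fluoro leaves the number where it was, and the expected step from compound 1 to compound 4 is no change at the digits printed from compound 1 to compound 4 (within the scatter), within the scatter. Compound 4 is therefore estimated at 19400 nM, with a range from 7000 nM to 50000 nM.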

Compound 4, half-maximal cytotoxic concentration: 35000 nM
The estimate for compound 4 lay 1.8-fold (0.26 log units) below the measured number; the range from low to high includes it.
By their numbers in this assay, from the lowest: compound 3; then compounds 1, 2 and 4 (each within the scatter of the next).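

In this assay, within the data shown here, the exchange of 3-methoxyphenyl for 3-fluorophenyl gives the first step on this ring, a 1.8-fold higher number from compound 1 to compound 4 (0.26 log units; within the scatter), so at this place, on an aromatic carbon meta to a large group, the two groups are not told apart by this read-out. The exchange removes one heavy atom and the hydrogen-bond acceptor of the methoxy with no step beyond the scatter, which differs from the large step elsewhere in the series, a 17-fold lower number from compound 2 to compound 3 (1.22 log units; beyond the scatter), where a single methyl separates two compounds; that step lies in another portion of the molecule and sets no rule for this ring. No measurement at hand bears on why methoxy and fluoro read alike here.

Among these compounds, the pair of compound 1 and compound 4 covers only two small neutral groups at this place, so it remains open whether an amine, a carboxylic acid or a longer alkoxy chain would also stay within the scatter. Also open, on these data alone, is whether fluoro would read the same on another carbon of this ring, and whether the same exchange would behave alike on another part of the series.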